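Methoxy for Cyano on the Benzylamine Substituent

The source may hold more compounds than are shown below. What is called first, only, known or untested is meant among the compounds shown, and "the series" means these compounds.

Among the compounds with values here, compound 2 `CN(Cc1ccc(COc2ccc3ccc(=O)oc3c2)cc1)Cc1cccc(C#N)c1` gives 5% in an assay for inhibition of Amine oxidase [flavin-containing] A (Rattus norvegicus), read by spectrophotometry, tested at 10 uM (on this read-out higher numbers stand for more inhibition at the one concentration tested (going by the name of the read-out) and lower numbers for less inhibition), the lower of the two numbers measured so far: compound 1 `CN(C)Cc1ccc(COc2ccc3ccc(=O)oc3c2)cc1` gives 17%, and the change is a number 12 percentage points lower from compound 1 to compound 2 (beyond the scatter). Compound 3 `COc1cccc(CN(C)Cc2ccc(COc3ccc4ccc(=O)oc4c3)cc2)c1` differs from compound 2 by methoxy in place of cyano on an aromatic carbon. Within the data shown here, no measured step exchanges one group for another on that ring; the only known step concerns the arrival of the whole 3-cyanophenyl group, so it bears on compound 3 only loosely. A step near zero, within the usual scatter, is therefore expected, a number 3 percentage points higher from compound 2 to compound 3 (within the scatter). Compound 3 is estimated at 8%, between 0% and 22%.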

Compound 3, a percentage reported as inhibition, at one concentration (the size of the read-out at that concentration, not a potency): 20%
Beside the measured number, compound 3's estimate is 12 percentage points below it; measured number inside the range.
By their numbers in this assay, from the lowest: compound 2; then compounds 1 and 3 (each within the scatter of the next).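

The group on this ring decides the outcome, not just the arrival of a ring at this place: in this assay, methoxy in place of cyano gives a number 15 percentage points higher from compound 2 to compound 3 (beyond the scatter). The drop seen with 3-cyanophenyl therefore does not extend to every substituted phenyl group, since 3-methoxyphenyl in place of hydrogen gives a number 3 percentage points higher from compound 1 to compound 3 (within the scatter). Nothing measured here explains the difference between the two groups. As far as these compounds go, whether a chlorine or a hydroxyl group on this aromatic carbon would track methoxy or cyano remains open.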